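The compounds below may be only part of what the source reports. "The series", "measured", "known", "first", "only" and "open" are said of these compounds alone.

Measured compounds:
Compound 1, `COc1ccc(/C=C/C(=O)c2ccncc2)cc1`, gives 6610 nM.
Compound 2, `CCOc1c(OC)cc(/C=C/C(=O)c2ccncc2)cc1OC`, gives 280 nM.
Compound 3, `CCOc1cc(/C=C/C(=O)c2ccncc2)cc(OCC)c1OCC`, gives 92 nM.

These three values come from an assay on HEK293 cells for inhibition of cytochrome P450 1A1 (Homo sapiens), read by fluorescence, with stated times of 30 min and 60 min; a lower number here means a stronger inhibitor, a higher number a weaker inhibitor. Compound 1 stands at the highest of the three numbers, which makes it the weakest inhibitor of the set. Compound 2 sits at a much lower number than compound 1, and compound 3 lower still, both gaps well beyond the usual scatter of this assay. The two stronger compounds share one feature: more alkoxy groups on the same ring of the shared core than compound 1 carries.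

Compound 4, `COc1ccc(/C=C/C(=O)c2ccncc2)cc1OC`, has not yet been measured. It differs from compound 1 in one place: methoxy in place of hydrogen on an aromatic carbon. This moves compound 4 part of the way toward the substitution pattern of compound 2 and compound 3. Within the data shown here, a step toward a lower number is therefore expected, but probably smaller than the gap from compound 1 to compound 2, since only one group is added. The estimated step of a 4.4-fold lower number from compound 1 to compound 4 (0.64 log units; beyond the scatter) is expected to lie beyond the scatter. For compound 4 the expected value is 1500 nM, within a range from 400 nM to 5000 nM.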

Compound 4, half-maximal inhibitory concentration: 420 nM
The estimate for compound 4 lay 3.6-fold (0.55 log units) above the measured number; measured number inside the range.
By their numbers in this assay, from the lowest: compound 3; then compounds 2 and 4 (each within the scatter of the next); then compound 1.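

In this assay, putting methoxy in place of hydrogen on an aromatic carbon, ortho to a methoxy group and meta to a large group, gives a 16-fold lower number from compound 1 to compound 4 (1.20 log units; beyond the scatter). Compound 2 and compound 3 each differ from compound 1 in more than one place, so they could not show what a single added group does; this pair shows that one methoxy at this position is enough for a large step, well beyond the scatter. Nothing available explains why this step is so large.

The compounds shown leave open whether the step is specific to methoxy, since an amine, a chlorine atom or a longer chain at this same place could give a different number. Also open, going by these compounds, is whether the same methoxy would give a similar step on a ring without the existing methoxy group.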